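From compound 3 to compound 4: a step beyond the limits

The source may hold more compounds than are shown below. What is called first, only, known or untested is meant among the compounds shown, and "the series" means these compounds.

Three compounds share one core: compound 1 `O=c1nc(N2CCN(NCCC3CCCCC3)CC2)sc2c([N+](=O)[O-])cc(C(F)(F)F)cc12`, compound 2 `CC(C)CN(CC(C)C)N1CCN(c2nc(=O)c3cc(C(F)(F)F)cc([N+](=O)[O-])c3s2)CC1` and compound 3 `CN(CC1CCCCC1)N1CCN(c2nc(=O)c3cc(C(F)(F)F)cc([N+](=O)[O-])c3s2)CC1`. In an ADME assay on Vero cells (Chlorocebus sabaeus) for cytotoxicity, read by MTT assay, with a stated time of 72 h (on this read-out higher numbers stand for lower toxicity in this test and lower numbers for higher toxicity in this test), compound 1 gives > 64 ug/mL, which is a limit and not a number. In this assay, compound 2 gives > 64 ug/mL, also a limit. In this assay, compound 3 gives > 64 ug/mL, again a limit. Compound 3 therefore has no number of its own and shares (the limit of > 64 ug/mL in this assay, at which 3 of the 3 values shown sit).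

Compound 4 `CON=C1CCC(N(C)N2CCN(c3nc(=O)c4cc(C(F)(F)F)cc([N+](=O)[O-])c4s3)CC2)CC1` differs from compound 3 by one change: a group of 9 heavy atoms (7 carbon, 1 nitrogen, 1 oxygen; one six-membered non-aromatic ring of carbon only) in place of a group of 7 heavy atoms (7 carbon; one six-membered non-aromatic ring of carbon only), on an amine nitrogen. Both groups carry one six-membered non-aromatic ring of carbon only, and the change sits on an amine nitrogen. The measured changes on that nitrogen are a step that the two limits leave unreadable from compound 1 to compound 3, a step that the two limits leave unreadable from compound 2 to compound 3 and a step that the two limits leave unreadable from compound 1 to compound 2, and none gives a size. From these, no step beyond the usual scatter is expected in this assay, in either direction. The estimated step is a step that the limit leaves unreadable from compound 3 to compound 4. Compound 4 is expected at 80 ug/mL, with an estimated range from 32 ug/mL to 128 ug/mL.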

Compound 4, half-maximal cytotoxic concentration: > 64 ug/mL
Compound 4 ended at the assay's limit; the forecaster's own chance of this, stated with the estimate: 85%; the middle value does not contradict the limit.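

In this assay compound 4 gives > 64 ug/mL, a limit and not a number, and its steps from compound 1, compound 2 and compound 3 cannot be read. The compounds shown leave open where the half-maximal cytotoxic concentration of any of the four lies, and whether changing these groups shifts it at all: the limit of > 64 ug/mL in this assay, at which 4 of the 4 values shown sit.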